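The source may report more compounds than this note shows. Statements on the series, on what has been measured and on what is new or still open speak of the compounds shown alone.

In a functional assay on PC-3 cells (Homo sapiens) for cytotoxicity, read by MTT assay, with a stated time of 48 h (a lower number here means a stronger inhibitor, a higher number a weaker inhibitor), compound 1 `COc1cc(-c2nnc3n2NC(c2ccco2)C(C(=O)c2cccc4ccccc24)S3)cc(OC)c1OC` gives > 100000 nM, which is a limit of the assay rather than a number. In this assay compound 2 `COc1ccc(C(=O)C2Sc3nnc(-c4cc(OC)c(OC)c(OC)c4)n3NC2c2ccco2)cc1` gives > 100000 nM, again a limit. Compound 2 therefore stands at the limit of > 100000 nM in this assay, at which 2 of the 2 values shown sit. Going by the values given here, the only measured step, a step that the two limits leave unreadable from compound 1 to compound 2, cannot be sized, since both of its ends sit at that limit. Compound 3 `COc1cc(-c2nnc3n2NC(c2ccco2)C(C(=O)c2cccc(Br)c2)S3)cc(OC)c1OC` differs from compound 2 by 3-bromophenyl in place of 4-methoxyphenyl on a carbonyl carbon. With no readable step to lean on, compound 3 is expected to remain near the same limit, an estimated 100000 nM with a range from 20000 nM to 500000 nM. The step of a number no higher from compound 2 to compound 3 (the limit leaves the size open) expected from this is none beyond the scatter.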

Compound 3, half-maximal inhibitory concentration: 63900 nM
Compound 3: middle estimate off by 1.6-fold (0.19 log units), on the high side; low and high end bracket the measured number.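

In this assay, going by these compounds alone, compound 3 is the only one of the three compounds that gives a number rather than a limit, so a change on this carbonyl carbon can bring the reading inside the measurable range. From the compounds shown here alone, the change reads as an at least 1.5-fold lower number from compound 2 to compound 3 (0.19 log units; that floor lies within the scatter), and as an at least 1.5-fold lower number from compound 1 to compound 3 (0.19 log units; that floor lies within the scatter); these are floors, so the true size stays unknown. The other two compounds remain at a limit: the limit of > 100000 nM in this assay, at which 2 of the 3 values shown sit.

Still open, going by these compounds, is how a plain phenyl or a 4-bromophenyl on this carbonyl carbon would read. Either could help show whether the reading goes with the bromine itself or with its place on the ring.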